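This account rests on a few compounds, and the source may have more. Where it says the series, first, only, none or still open, it means among the compounds named here.

Values so far in a functional assay, with a stated time of 30 min; on this read-out lower numbers stand for stronger inhibition and higher numbers for weaker inhibition:

- compound 1 `O=C(/C=C/c1cccc(O)c1)CC(=O)/C=C/c1cc(O)ccc1O` gives 88000 nM here
- compound 2 `O=C(/C=C/c1ccc(O)c(O)c1)/C=C/c1ccccc1O` gives 62000 nM here
- compound 3 `O=C(/C=C/c1cccc(O)c1)/C=C/c1ccc(O)c(O)c1` gives 71000 nM here

Compound 3 at 71000 nM cannot be separated from compound 2 or compound 1, since it lies within the scatter of both. The three numbers form a single band.

The next comparison is with compound 4 `O=C(/C=C/c1ccc(O)cc1)/C=C/c1ccc(O)c(O)c1` and the change is 4-hydroxyphenyl in place of 3-hydroxyphenyl on a double-bonded chain carbon bound to a double-bonded chain carbon with 4-hydroxyphenyl in place of 3-hydroxyphenyl on a double-bonded chain carbon bound to a double-bonded chain carbon. Among the measured compounds shown here, no measured compound carries 4-hydroxyphenyl in that place, so the data hold no direct precedent for it.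

For the measured compounds named here, one measured step bears on the change: a 1.1-fold higher number from compound 2 to compound 3 (0.06 log units; within the scatter) with 3-hydroxyphenyl in place of 2-hydroxyphenyl on a double-bonded chain carbon bound to a double-bonded chain carbon. That step is small, but it is a single comparison. No step beyond the scatter is therefore expected in this assay and neither direction is favoured.

The expected outcome is a 1.1-fold lower number from compound 3 to compound 4 (0.04 log units; within the scatter) and this estimated step stays within the scatter. For compound 4 the estimate is 65000 nM with 35000 nM to 110000 nM as the expected range.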

Compound 4, half-maximal inhibitory concentration: 24000 nM
For compound 4 the middle estimate is 2.7-fold (0.43 log units) above the measured one; the whole stated range lies above it.
By their numbers in this assay, from the lowest: compound 4; then compounds 2, 3 and 1 (each within the scatter of the next).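

In this assay, the place on a double-bonded chain carbon bound to a double-bonded chain carbon now proves sensitive to which hydroxyphenyl group it carries: 4-hydroxyphenyl in place of 3-hydroxyphenyl gives a 3.0-fold lower number from compound 3 to compound 4 (0.47 log units; beyond the scatter), and 4-hydroxyphenyl in place of 2-hydroxyphenyl gives a 2.6-fold lower number from compound 2 to compound 4 (0.41 log units; beyond the scatter). The earlier comparison, a 1.1-fold higher number from compound 2 to compound 3 (0.06 log units; within the scatter), did not separate 2-hydroxyphenyl from 3-hydroxyphenyl, so among these three groups in this place, only 4-hydroxyphenyl stands apart, and by modest steps. No available measurement bears on why this change lowers the number.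

The compounds shown leave open whether the lower number depends on the hydroxy group itself, which a 4-methoxyphenyl or 4-aminophenyl group in the same place would test. They also leave open whether 4-hydroxyphenyl gives a step of similar size on a core other than that of compound 4, such as the longer chain of compound 1, or when a carboxylic acid is carried on the ring in place of the hydroxy group.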